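The compounds below may be only part of what the source reports. "The series", "measured", "known", "first", "only" and "open" are said of these compounds alone.

Working notes on the series. Compound 1 `Cc1ccsc1/C=C(/SCc1ccc(Cl)cc1)C(=O)c1ccc(Cl)cc1` serves as the reference point; in a functional assay on DU-145 cells (Homo sapiens) for inhibition, read by trypan blue exclusion, with a stated time of 96 h (on this read-out higher numbers stand for weaker inhibition of growth and lower numbers for stronger inhibition of growth), compound 1 gives 50000 nM. Compound 2 `COc1ccccc1/C=C(/SCc1ccc(Cl)cc1)C(=O)c1ccc(Cl)cc1` differs from it in one place, (2-methoxyphenyl in place of 3-methylthiophen-2-yl on a double-bonded chain carbon bound to a double-bonded chain carbon), and in this assay compound 2 gives 1000 nM, which amounts to a 50-fold lower number from compound 1 to compound 2 (1.70 log units; beyond the scatter). Compound 3 `Cc1ccc(CS/C(=C/c2sccc2C)C(=O)c2ccc(Cl)cc2)cc1` differs from compound 1 in another place, (methyl in place of chloro on an aromatic carbon), and in this assay compound 3 gives 10000 nM, which amounts to a 5.0-fold lower number from compound 1 to compound 3 (0.70 log units; beyond the scatter). Within the data shown here, no step between compound 2 and compound 3 is counted here; their two values simply stand apart as given.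

Compound 4 `COc1ccccc1/C=C(/SCc1ccc(C)cc1)C(=O)c1ccc(Cl)cc1` has not been measured. Against compound 3 the difference is 2-methoxyphenyl in place of 3-methylthiophen-2-yl on a double-bonded chain carbon bound to a double-bonded chain carbon. Among the measured compounds shown here, this is the same change as the one made from compound 1 to compound 2, at the same place, and the two cores on which it is made differ only by the earlier difference between compound 1 and compound 3.

For the measured compounds named here, the step that the change made once, a 50-fold lower number from compound 1 to compound 2 (1.70 log units; beyond the scatter), is the sole guide. A single occurrence on a different core does not guarantee repetition, so the expectation is held a little short of it and given a wide range. The expected step is a 40-fold lower number from compound 3 to compound 4 (1.60 log units; beyond the scatter) in this assay. Compound 4 is expected to give 250 nM in this assay, with a range from 60 nM to 1500 nM.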

Compound 4, concentration for 50% growth inhibition: 10000 nM
For compound 4 the middle estimate is 40-fold (1.60 log units) below the measured one; the measured number lies above the stated range.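

In this assay, putting 2-methoxyphenyl in place of 3-methylthiophen-2-yl on the core of compound 3 gives no change at the digits printed from compound 3 to compound 4 (within the scatter), so the large drop seen on the core of compound 1 does not carry over to this core: the same change on two cores in this assay, a 50-fold lower number (1.70 log units; beyond the scatter) from compound 1 to compound 2 and no change at the digits printed (within the scatter) from compound 3 to compound 4, 50-fold (1.70 log units) apart, beyond the scatter of two such steps

The other change depends on the core as well: methyl in place of chloro on an aromatic carbon gives a 10-fold higher number from compound 2 to compound 4 (1.00 log units; beyond the scatter), the opposite direction to the step it gives on the core of compound 1: the same change on two cores in this assay, a 5.0-fold lower number (0.70 log units; beyond the scatter) from compound 1 to compound 3 and a 10-fold higher number (1.00 log units; beyond the scatter) from compound 2 to compound 4, 50-fold (1.70 log units) apart, beyond the scatter of two such steps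

Within these four compounds, the two changes therefore do not act independently, and the size of either step cannot be read from the other core; this does not show why they depend on each other, nor does a single set of four compounds show that such dependence holds across the wider series.

On these data alone, it remains open whether the same dependence would appear with a trifluoromethyl group, an amine or a carboxylic acid on that aromatic carbon in place of the methyl or chloro. As far as these compounds go, it also remains open whether an unsubstituted phenyl or a longer alkoxy chain on the phenyl ring, in place of 2-methoxyphenyl, would keep the lower number of compound 2 on the chloro core.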